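From Compound 1 to Compound 4 in Lipophilicity

The source may hold more compounds than are shown below. What is called first, only, known or untested is meant among the compounds shown, and "the series" means these compounds.

Compound 1 `Cc1cc(C(=O)NCc2ccncc2)nn1Cc1cc(Cl)ccc1OCc1ccccc1` was measured in a physicochemical assay for lipophilicity, at pH 7.4 (a lower number here means a more polar compound, a higher number a more lipophilic compound), where compound 1 gives > 3.7, a limit of the assay rather than a number. Compound 2 `Cc1cc(C(=O)NN2CCCCC2)nn1Cc1cc(Cl)ccc1OCC(C)C` gives 3.3 in this assay. Compound 3 `Cc1cc(C(=O)NN2CCOCC2)nn1Cc1cc(Cl)ccc1OCC(C)C` gives 3.1. For the measured compounds named here, the one measured step, a number 0.20 log units lower from compound 2 to compound 3 (within the scatter), concerns a different part of the shared core and does not bear directly on the change to compound 4 `Cc1cc(NC(=O)O[C@H]2CCOC2)nn1Cc1cc(Cl)ccc1OCc1ccccc1`: (((oxolan-3-yl)oxy)carbonyl)amino in place of ((pyridin-4-yl)methyl)carbamoyl on an aromatic carbon. Because compound 1 sits at the limit of > 3.7 in this assay, at which 1 of the 3 values shown sits, only a starting point at that limit is known. Going by the values given here, with no comparable step measured, a shift no larger than the scatter is expected, so compound 4 is estimated at 3.8 (range 3.2 to 4.4), an expected step that the limit leaves unreadable from compound 1 to compound 4.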

Compound 4, distribution coefficient: 2.7
Estimate against measurement, compound 4: 1.10 log units above; the measured number lies below the stated range.
By their numbers in this assay, from the lowest: compound 4; then compounds 3 and 2 (each within the scatter of the next). At a limit, above all of these: compound 1.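

In this assay, (((oxolan-3-yl)oxy)carbonyl)amino in place of ((pyridin-4-yl)methyl)carbamoyl on this aromatic carbon gives a number at least 1.00 log units lower from compound 1 to compound 4 (beyond the scatter). For the compounds shown here, the only earlier step, a number 0.20 log units lower from compound 2 to compound 3 (within the scatter), was a change on an amide-type nitrogen, whereas this change to the group on the aromatic carbon goes beyond the scatter. The full size of this step stays unknown because compound 1 gives only a limit: the limit of > 3.7 in this assay, at which 1 of the 4 values shown sits.

The ring and the link to the core change together here, and the compounds shown do not separate the two. On these data alone, how an amine or a carboxylic acid on this aromatic carbon would read in this assay remains open.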